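Pyridin-2-yl to 2-acetamido-1,3-thiazol-5-yl: clearance outlook

The compounds below may be only part of what the source reports. "The series", "measured", "known", "first", "only" and "open" are said of these compounds alone.

Values in an ADME assay (liver) for metabolic stability, with Liver microsome (Homo sapiens) as the target, read by LC-MS, using microsomes and NADPH, with a stated time of 5 min, at 37 degrees C; on this read-out lower numbers stand for slow clearance and higher numbers for fast clearance:
Compound 1 `CCn1c(C(C)NS(=O)(=O)c2ccc(Cl)cc2)nc2cccnc21` gives 94 mL.min-1.g-1.
Compound 2 `CCn1c([C@@H](C)NS(=O)(=O)c2cccc(C#N)c2)nc2ccc(C(F)(F)F)cc21` gives > 100 mL.min-1.g-1, which is a limit of the assay.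
Compound 3 `CCn1c([C@@H](C)NS(=O)(=O)c2ccccn2)nc2ccc(C(F)(F)F)cc21` gives < 3 mL.min-1.g-1, also a limit of the assay.

Compound 3 therefore stands at the slow end, at the limit of < 3 mL.min-1.g-1 in this assay, at which 1 of the 3 values shown sits, and only a limit is known for it. Compound 4 `CCn1c([C@@H](C)NS(=O)(=O)c2cnc(NC(C)=O)s2)nc2ccc(C(F)(F)F)cc21` differs from it in one place: 2-acetamido-1,3-thiazol-5-yl in place of pyridin-2-yl on a sulfonyl sulfur. Among the compounds with values here, the only measured step at the sulfonyl sulfur is an at least 33-fold lower number from compound 2 to compound 3 (1.52 log units; beyond the scatter), running from the limit of > 100 mL.min-1.g-1 in this assay, at which 1 of the 3 values shown sits, down to the lower limit. That step installed pyridin-2-yl; the present step removes it again, so the slow reading of compound 3 need not carry over. A moderate rise is expected, an at least 5.0-fold higher number from compound 3 to compound 4 (0.69 log units; beyond the scatter), giving compound 4 an estimated 15 mL.min-1.g-1, within 3 mL.min-1.g-1 to 70 mL.min-1.g-1.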

Compound 4, intrinsic clearance in microsomes: 15 mL.min-1.g-1
Estimate against measurement, compound 4: no gap at the digits printed; measured number inside the range.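

In this assay, a low number at the sulfonyl sulfur does not rest on pyridin-2-yl alone: 2-acetamido-1,3-thiazol-5-yl in place of 3-cyanophenyl gives an at least 6.6-fold lower number from compound 2 to compound 4 (0.82 log units; beyond the scatter) and so keeps much of the drop. Yet the two groups do not read alike here, with an at least 5.0-fold higher number from compound 3 to compound 4 (0.69 log units; beyond the scatter) as the cost of the swap. Both steps are bounds, not exact sizes, since each starts from a limit of the assay.

As far as these compounds go, whether 2-amino-1,3-thiazol-5-yl would read like compound 4 stays open. Also open is the true value of compound 3, known only as a limit: the limit of < 3 mL.min-1.g-1 in this assay, at which 1 of the 4 values shown sits.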